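The source may report more compounds than this note shows. Statements on the series, on what has been measured and on what is new or still open speak of the compounds shown alone.

In a functional assay on SK-OV-3 cells (Homo sapiens) for cytotoxicity, read by sulforhodamine B assay, with a stated time of 2 days, tested at 100 uM (on this read-out higher numbers stand for more inhibition at the one concentration tested (going by the name of the read-out) and lower numbers for less inhibition), compound 1 `COc1cccc(-c2nc3c(-c4ccc(Cl)cc4)n[nH]c3c(=O)n2NC(=O)c2ccncc2)c1` gives 42.5%, the higher of the two numbers recorded so far. For the measured compounds named here, compound 2 `COc1cccc(-c2nc3c(-c4ccc(C5CCNCC5)cc4)n[nH]c3c(=O)n2NC(=O)c2ccncc2)c1` gives 18.2% in this assay, and the step of a number 24.3 percentage points lower from compound 1 to compound 2 (beyond the scatter) is the only measured change; it concerns a group on an aromatic carbon, not the amide end of the molecule. Compound 3 `COc1cccc(-c2nc3c(-c4ccc(Cl)cc4)n[nH]c3c(=O)n2NC(=O)c2ccccc2)c1` is still to be measured. It differs from compound 1 by phenyl in place of pyridin-4-yl on a carbonyl carbon. Going by the values given here, no measured pair carries this exchange, so the single known step gives no direct guidance for it. What leaves and what enters are each one six-membered aromatic ring of six heavy atoms, and the change is therefore expected to give no step beyond the scatter in this assay. Compound 3 is thus estimated at 40%, between 25% and 55%. The expected step of a number 2.5 percentage points lower from compound 1 to compound 3 (within the scatter) stays within the usual scatter.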

Compound 3, a percentage reported as inhibition, at one concentration (the size of the read-out at that concentration, not a potency): 81.7%
Compound 3: the middle estimate sits 41.7 percentage points below what was measured, outside the stated range (above it).
By their numbers in this assay, from the lowest: compound 2; then compound 1; then compound 3.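

In this assay, the exchange on the carbonyl carbon gives a number 39.2 percentage points higher from compound 1 to compound 3 (beyond the scatter), so this end of the molecule affects the read-out even though phenyl and pyridin-4-yl are each one six-membered aromatic ring of six heavy atoms. As counted, the two groups differ in the ring nitrogen and its single hydrogen-bond acceptor, but this pair alone cannot show that this difference accounts for the step. No measurement available here explains the step.

From the compounds shown here alone, it remains open whether the same exchange gives a comparable step with piperidin-4-yl in place of chloro, as in compound 2. Going by these compounds, it is also open how the read-out responds to an amino or methoxy group on the phenyl ring, or to a saturated cyclohexyl ring in its place.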